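The source may report more compounds than this note shows. Statements on the series, on what has been measured and on what is new or still open speak of the compounds shown alone.

Measured so far in this study:
- compound 1, `Nc1ccccc1NC(=O)c1ccc(CNC(=O)c2n[nH]cc2NC(=O)c2c(F)cccc2Cl)cc1`: 1200 nM
- compound 2, `Nc1ccccc1NC(=O)c1ccc(CNC(=O)c2n[nH]cc2NC(=O)c2c(Cl)cccc2Cl)cc1`: 1200 nM
- compound 3, `O=C(NO)c1ccc(CNC(=O)c2n[nH]cc2NC(=O)c2ccccc2F)cc1`: 3010 nM

All three were tested in a functional assay on A-375 cells (Homo sapiens) for inhibition, read by CCK-8 assay, with a stated time of 72 h; on this read-out higher numbers stand for weaker inhibition and lower numbers for stronger inhibition. In this assay compound 1 gives 1200 nM, and compound 2, which differs from it by chloro in place of fluoro on an aromatic carbon, gives 1200 nM; the step between them is no change at the digits printed from compound 1 to compound 2 (within the scatter). Compound 3 gives 3010 nM, the highest of the three numbers; the difference between its core and the core of compound 1 is not broken down here.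

Compound 4, `O=C(NO)c1ccc(CNC(=O)c2n[nH]cc2NC(=O)c2ccccc2Cl)cc1`, has not been measured yet. It differs from compound 3 by chloro in place of fluoro on an aromatic carbon. The surroundings are not identical: in compound 1 the place of change is also meta to a chloro group, which compound 3 lacks, so this is the same kind of change rather than the same one. Because no change at the digits printed from compound 1 to compound 2 (within the scatter) shows no movement, a similarly small step is expected from compound 3 to compound 4, a 1.0-fold lower number from compound 3 to compound 4 (0.00 log units; within the scatter). Compound 4 is therefore estimated at about 3000 nM, expected to fall between 1500 nM and 6000 nM.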

Compound 4, half-maximal inhibitory concentration: 6420 nM
Estimate against measurement, compound 4: 2.1-fold (0.33 log units) below; the whole stated range lies below it.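

In this assay, putting chloro in place of fluoro on the core of compound 3 gives a 2.1-fold higher number from compound 3 to compound 4 (0.33 log units; beyond the scatter), a modest loss of inhibition that lies beyond the usual scatter. Set beside the same change on the core of compound 1, this step cannot be told apart from the earlier one: the same change on two cores in this assay, no change at the digits printed (within the scatter) from compound 1 to compound 2 and a 2.1-fold higher number (0.33 log units; beyond the scatter) from compound 3 to compound 4, 2.1-fold (0.33 log units) apart, within the scatter of two such steps. Within the data shown here, this does not prove that the change behaves identically on both cores, nor does it show that the core alters the outcome, since each core offers only one pair and the ring of compound 1 also carries a further chloro that compound 3 lacks.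

The compounds shown leave open whether the step on the core of compound 3 would look the same with that further chloro present. They also leave open how a methyl or a methoxy group at the same place would compare with fluoro and chloro on either core.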